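A few compounds are considered here, and "the series" means these few. Any claim that something is new, unique, unknown or untested is made for them only; others in the source may bear on it.

In an ADME assay on a cell-free system (plasma, Mus musculus) for protein binding, using equilibrium dialysis, with a stated time of 4 h, tested at 5 uM (on this read-out lower numbers stand for a smaller free fraction and higher numbers for a larger free fraction), compound 1 (`O=C(NCc1ccc(S(=O)(=O)c2ccccc2)cc1)N1Cc2ccncc2C1`) gives 0.093 and compound 2 (`CC(C)n1cc(S(=O)(=O)c2ccc(CNC(=O)N3Cc4ccncc4C3)cc2)cn1`) gives 0.12, so compound 2 stands within the scatter of compound 1. Compound 3 (`O=C(NCc1ccc(S(=O)(=O)C2CCN(C3COC3)CC2)cc1)N1Cc2ccncc2C1`) has 1-(oxetan-3-yl)piperidin-4-yl in place of 1-isopropyl-1H-pyrazol-4-yl on a sulfonyl sulfur. Among the measured compounds shown here, only one measured step bears on this place: a 1.3-fold higher number from compound 1 to compound 2 (0.11 log units; within the scatter), with 1-isopropyl-1H-pyrazol-4-yl in place of phenyl, and it stays within the scatter. For the measured compounds named here, no measured compound carries a non-aromatic ring on the sulfonyl sulfur, so that step is only a weak guide. In this assay the expected change is therefore small and toward a larger free fraction, an estimated 1.7-fold higher number from compound 2 to compound 3 (0.22 log units; within the scatter) that does not clearly leave the scatter. For compound 3 the estimated value is 0.2, with an expected range from 0.1 to 0.4.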

Compound 3, unbound fraction in the plasma assay: 0.078
For compound 3 the middle estimate is 2.6-fold (0.41 log units) above the measured one; the whole stated range lies above it.
By their numbers in the plasma assay, from the lowest: compounds 3, 1 and 2 (each within the scatter of the next).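

In the plasma assay the move to a non-aromatic ring on the sulfonyl sulfur gives a 1.5-fold lower number from compound 2 to compound 3 (0.19 log units; within the scatter) and a 1.2-fold lower number from compound 1 to compound 3 (0.08 log units; within the scatter). Among the compounds shown here, the 1-(oxetan-3-yl)piperidin-4-yl group therefore stands with the phenyl and 1-isopropyl-1H-pyrazol-4-yl groups, and this position has now taken aromatic and non-aromatic rings with no step in free fraction beyond the scatter. In a physicochemical assay for solubility, in phosphate buffer, with a stated time of 24 h, at pH 7.4, tested at 100 uM (on this read-out higher numbers stand for higher solubility and lower numbers for lower solubility), the same change gives a 1.6-fold lower number from compound 2 to compound 3 (0.20 log units; within the scatter), with compound 2 at 192000 nM and compound 3 at 121000 nM, and nothing available gives a reason for these results.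

On these data alone, whether any group on the sulfonyl sulfur can carry either read-out beyond the scatter remains open. A carboxylic acid, a primary amine or an open alkyl chain in this place would test that.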